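A few compounds are considered here, and "the series" means these few. Any claim that something is new, unique, unknown or untested is made for them only; others in the source may bear on it.

Of the compounds shown here, two built on a shared core have been measured in a functional assay on RXF 393 cells (Homo sapiens) for inhibition, read by sulforhodamine B assay, with a stated time of 48 h; on this read-out higher numbers stand for weaker inhibition of growth and lower numbers for stronger inhibition of growth. Compound 1, `O=C(Nc1cccc(-n2cc(-c3ccncc3)c(-c3ccc(Cl)c(O)c3)n2)c1)Nc1ccc(Cl)c(Cl)c1`, gives 1000 nM in this assay. Compound 2, `O=C(Nc1cccc(-n2cc(-c3ccncc3)c(-c3ccc(Cl)c(O)c3)n2)c1)Nc1cc(C(F)(F)F)cc(C(F)(F)F)c1`, gives 937 nM in this assay. The two values lie within the usual scatter of each other, so nothing can be read into their gap. Compound 1 thus stands at the higher of the two numbers, but only by a margin that repeated measurements would blur.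

Compound 3, `O=C(Nc1cccc(-n2cc(-c3ccncc3)c(-c3ccc(Cl)c(O)c3)n2)c1)Nc1ccc(Cl)c(C(F)(F)F)c1`, has not been measured. It differs from compound 1 in one place: trifluoromethyl in place of chloro on an aromatic carbon. Among the compounds with values here, no pair of measured compounds shows what this exchange does, and the only other comparison at hand, compound 1 against compound 2, shows two values that sit on top of each other. The expected step from compound 1 to compound 3 is therefore a 1.1-fold lower number from compound 1 to compound 3 (0.02 log units; within the scatter), a change no larger than the scatter, with no clear direction. Compound 3 is estimated at 950 nM in this assay, with a likely range from 400 nM to 2200 nM.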

Compound 3, concentration for 50% growth inhibition: 508 nM
Compound 3: the middle estimate sits 1.9-fold (0.27 log units) above what was measured; measured number inside the range.
By their numbers in this assay, from the lowest: compounds 3, 2 and 1 (each within the scatter of the next).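

Within the data shown here, exchanging chloro for trifluoromethyl on this aromatic carbon, ortho to a chloro group, is the first single change that can be read directly, and in this assay it gives a 2.0-fold lower number from compound 1 to compound 3 (0.29 log units; within the scatter). A step of this size cannot be told apart from the differences seen between repeated measurements, so it should not be read as a real gain in growth inhibition. What it does show is that this position can carry trifluoromethyl, with its four heavy atoms, in place of the single atom of chloro without any measurable loss of growth inhibition, and no measurement at hand explains why the two groups read alike.

All the compounds shown carry chloro or trifluoromethyl on this ring, so it remains open whether an amine, a carboxylic acid or a methoxy group at this position would keep growth inhibition or lose it. Also open, on these data alone, is whether the same exchange would read alike with the chloro group it sits ortho to taken away, since this single pair tests it in one setting only.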